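The compounds below may be only part of what the source reports. "The series", "measured", "known", "first", "only" and "open" are said of these compounds alone.

Of the compounds shown here, three have so far been measured in an ADME assay on Caco-2 cells (Homo sapiens) for permeability, read by LC-MS, in the apical to basolateral direction, with a stated time of 60 min, at pH 6.5; a lower number here means that the compound crosses the layer more slowly, a higher number that the compound crosses the layer faster. Compound 1 `CC(C)(C)[C@@H](O)C(=O)N1CSC[C@H]1C(=O)NCc1cc(Cl)ccc1-n1cnnn1` gives 19 10^-6 cm/s. Compound 2 `COC(C)(C)[C@@H](O)C(=O)N1[C@H](C(=O)NCc2cc(Cl)ccc2-n2cnnn2)C[C@@H]2C[C@@H]21` gives 16 10^-6 cm/s, the second highest of the three numbers; its gap to compound 1 lies within the usual scatter, whereas compound 3 `O=C(NCc1cc(Cl)ccc1-n1cnnn1)[C@@H]1[C@@H]2C[C@@H]2CN1C(=O)[C@H](O)c1ccccc1` gives 2.2 10^-6 cm/s, a number well beyond the scatter below compound 2. Compound 4 `O=C(NCc1cc(Cl)ccc1-n1cnnn1)[C@@H]1C[C@@H]2C[C@@H]2N1C(=O)[C@H](O)c1ccccc1` has not yet been measured. It differs from compound 2 in one place: phenyl in place of 1-methoxy-1-methylethyl on a saturated chain carbon bound to a carbonyl carbon and an oxygen on a saturated carbon. Within the data shown here, no step of exactly this kind has been measured. Compound 3, however, carries the same hydroxy(phenyl)methyl group on a closely related core and gives 2.2 10^-6 cm/s. On that basis a drop beyond the scatter is expected: a 4.6-fold lower number from compound 2 to compound 4 (0.66 log units; beyond the scatter). Compound 4 is therefore estimated at 3.5 10^-6 cm/s, within a range from 1.2 10^-6 cm/s to 10 10^-6 cm/s.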

Compound 4, apparent permeability: 8 10^-6 cm/s
For compound 4 the middle estimate is 2.3-fold (0.36 log units) below the measured one; low and high end bracket the measured number.
By their numbers in this assay, from the lowest: compound 3; then compounds 4, 2 and 1 (each within the scatter of the next, the first and the last beyond it).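

In this assay, phenyl in place of 1-methoxy-1-methylethyl on a saturated chain carbon bound to a carbonyl carbon and an oxygen on a saturated carbon gives a 2.0-fold lower number from compound 2 to compound 4 (0.30 log units; within the scatter) as the first step read at this position. On this shared core, an open chain and a six-membered aromatic ring of carbon only therefore give numbers that cannot be told apart here. No measured evidence explains this result. Other groups at this position, such as an amine or a carboxylic acid, remain open, as does the same change on the core of compound 1.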